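Dropping the ester from compound 3

The source may report more compounds than this note shows. Statements on the series, on what has been measured and on what is new or still open speak of the compounds shown alone.

Measured so far in an assay on nucleic acid for inhibition of Nucleic Acid, read by fluorescence, tested at 100 uM; on this read-out lower numbers stand for less inhibition and higher numbers for more inhibition at the one concentration tested (going by the name of the read-out):
compound 1 `CN(CCCc1ccccc1)Cc1cn(C2CCCCC2OC(=O)COc2ccccc2)nn1` gives 42%;
compound 2 `CCOC(=O)C1CCCN(Cc2cn(C3CCCCC3OC(=O)COc3ccccc3)nn2)C1` gives 21%;
compound 3 `CCCCN(CCCC)Cc1cn(C2CCCCC2OC(=O)COc2ccccc2)nn1` gives 26%.

Compound 3 stands second highest of the three in this assay: the step of a number 5 percentage points higher from compound 2 to compound 3 (within the scatter) stays within the scatter, whereas a number 16 percentage points lower from compound 1 to compound 3 (beyond the scatter). Compound 4 `CCCCN(CCCC)Cc1cn(C2CCCCC2O)nn1` differs from compound 3 in one place: hydrogen in place of (phenoxymethyl)carbonyl on an oxygen on a saturated carbon. Within the data shown here, every measured step here changes the amine on the saturated chain carbon bound to an aromatic carbon, the larger ones being a number 21 percentage points lower from compound 1 to compound 2 (beyond the scatter) and a number 16 percentage points lower from compound 1 to compound 3 (beyond the scatter); none touches the oxygen on the saturated carbon, so no measured step bears directly on this change. Compound 4 is therefore estimated to give 18%, between 4% and 36%. The expected step of a number 8 percentage points lower from compound 3 to compound 4 (within the scatter) is, on these numbers, modest and uncertain in direction.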

Compound 4, a percentage reported as inhibition, at one concentration (the size of the read-out at that concentration, not a potency): 32%
Beside the measured number, compound 4's estimate is 14 percentage points below it; measured number inside the range.
By their numbers in this assay, from the lowest: compounds 2, 3, 4 and 1 (each within the scatter of the next, the first and the last beyond it).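

In this assay, among these compounds, hydrogen in place of (phenoxymethyl)carbonyl on the oxygen gives a number 6 percentage points higher from compound 3 to compound 4 (within the scatter) and is the first reading at this position. With the dibutylamino group in place, this whole group of 10 heavy atoms, its six-membered aromatic ring included, can therefore be removed without the read-out moving beyond the scatter. No evidence is at hand on what lies behind this result.

As far as these compounds go, whether the same holds with the methyl(3-phenylpropyl)amino group of compound 1 stays open. Also open, from the compounds shown here alone, is how an acetyl group on this oxygen, or an amine in its place, would read.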